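This account rests on a few compounds, and the source may have more. Where it says the series, first, only, none or still open, it means among the compounds named here.

Compound 2 `Cc1cc(C)cc(SCc2ccc(/C=C/C(=O)Nc3ccccc3N)cc2)c1`, compound 1 `COc1ccc(SCc2ccc(/C=C/C(=O)Nc3ccccc3N)cc2)cc1OC` and compound 3 `CC(C)(C)c1ccc(SCc2ccc(C(=O)Nc3ccccc3N)cc2)cc1` share one core and differ in the group carried by the sulfur. In a functional assay on HCT-116 cells (Homo sapiens) for inhibition, read by CCK-8 assay, with a stated time of 72 h, tested at 2 uM (a higher number here means more inhibition of growth at the concentration tested, a lower number less inhibition of growth), compound 2 gives 7.98%; compound 1 gives 12.9% and compound 3 gives 4.81%, so the three numbers all lie within the scatter of one another, and compound 2 stands second of them only by this narrow margin. Compound 4 `Nc1ccccc1NC(=O)/C=C/c1ccc(CSc2ccc(C(F)(F)F)cn2)cc1` arises from compound 2 by 5-(trifluoromethyl)pyridin-2-yl in place of 3,5-dimethylphenyl on a sulfur. Among the compounds with values here, the only measured step at the same place, a number 4.9 percentage points lower from compound 1 to compound 2 (within the scatter), is within the scatter, so no step beyond the scatter is expected here either. Compound 4 is therefore expected to give 10%, with a range from 0% to 22%, an expected step of a number 2 percentage points higher from compound 2 to compound 4 (within the scatter).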

Compound 4, percent growth inhibition at one concentration: 4.42%
Compound 4: middle estimate off by 5.6 percentage points, on the high side; measured number inside the range.
By their numbers in this assay, from the lowest: compounds 4, 3, 2 and 1 (each within the scatter of the next).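

In this assay, placing 5-(trifluoromethyl)pyridin-2-yl on the sulfur gives a number 3.6 percentage points lower from compound 2 to compound 4 (within the scatter) and a number 8.5 percentage points lower from compound 1 to compound 4 (within the scatter) as its two steps. The earlier compounds shown here carried only aromatic rings of carbon at this place, and this first ring with a hetero atom, bearing trifluoromethyl, still produces no step beyond the scatter. No measurement here accounts for these numbers.

The compounds shown leave open whether a saturated ring, an amine or a carboxylic acid on the sulfur would move the number beyond the scatter.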